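Swapping a Piperazine Substituent: Expected Rat Tissue Distribution

A few compounds are considered here, and "the series" means these few. Any claim that something is new, unique, unknown or untested is made for them only; others in the source may bear on it.

Compound 1, `COc1cc2nnc(C(N)=O)c(Nc3ccc(C)cc3F)c2cc1N1CCN(C)CC1`, gives 3.8 L/kg in an ADME assay on the whole organism for pharmacokinetics, with Rattus norvegicus as the target; on this read-out higher numbers stand for wider distribution into tissues and lower numbers for narrower distribution.
Compound 2, `COc1cc2nnc(C(N)=O)c(Nc3ccc(C)cc3F)c2cc1N1CCN(C(C)C)CC1`, gives 3.8 L/kg in this assay.
Compound 3, `COc1cc2nnc(C(N)=O)c(Nc3ccc(C)cc3F)c2cc1N1C[C@@H](C)N[C@@H](C)C1`, is not yet measured in this assay.

Compound 2 stands level with compound 1 on the numbers shown; the only measured step, no change at the digits printed from compound 1 to compound 2 (within the scatter), lies within the scatter. The move to compound 3 is 3,5-dimethylpiperazin-1-yl in place of 4-isopropylpiperazin-1-yl on an aromatic carbon. Within the data shown here, the one step already known changes the group on the amine nitrogen of the same ring, and it produced no shift beyond the scatter, so it is the nearest guide, though the new change also brings in a hydrogen-bond donor and moves the methyl groups onto ring carbons, which no measured pair covers. On that basis no step beyond the scatter is expected in this assay, so the expected step is no change at the digits printed from compound 2 to compound 3 (within the scatter). Compound 3 is therefore estimated at 3.8 L/kg, with a range from 1.9 L/kg to 7.6 L/kg.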

Compound 3, volume of distribution at steady state: 1.6 L/kg
Compound 3: the middle estimate sits 2.4-fold (0.38 log units) above what was measured; the measured number lies below the stated range.
By their numbers in this assay, from the lowest: compound 3; then compounds 1 and 2 (each within the scatter of the next).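

Unlike the earlier swap on the ring nitrogen, this change at the same aromatic carbon moves the number in this assay: 3,5-dimethylpiperazin-1-yl brings a 2.4-fold lower number from compound 2 to compound 3 (0.38 log units; beyond the scatter), and measured against 4-methylpiperazin-1-yl it brings a 2.4-fold lower number from compound 1 to compound 3 (0.38 log units; beyond the scatter). The position is therefore not indifferent to every change, and the same result from both starting points shows that the two groups on the ring nitrogen, level with each other here, make no difference to the size of this drop. The entering group differs in several ways at once, with 1 hydrogen-bond donor, methyl groups on ring carbons and 2 defined stereocentres, and nothing available here explains the lower number.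

Plain piperazin-1-yl would separate the free ring amine from the ring methyl groups, and 3,4,5-trimethylpiperazin-1-yl would test the same ring methyl groups with the ring nitrogen capped. From the compounds shown here alone, the other stereoisomers of the 3,5-dimethylpiperazin-1-yl group also remain open.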